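The compounds below may be only part of what the source reports. "The series", "measured", "known", "first", "only" and "open" are said of these compounds alone.

Compound 1 `Cc1nsc2[nH]c(SCc3ccccc3)nc12` and compound 2 `c1ccc(CSc2nc3cnsc3[nH]2)cc1` share one core and differ in a single place. In a functional assay on L1210 cells (Mus musculus) for antiproliferative activity (on this read-out lower numbers stand for stronger inhibition and higher numbers for weaker inhibition), compound 1 gives 7000 nM, while compound 2 gives 300 nM. That change, (hydrogen in place of methyl on an aromatic carbon), brings a 23-fold lower number from compound 1 to compound 2 (1.37 log units; beyond the scatter).

Compound 3 `CSc1nc2c(C)nsc2n1[C@@H]1O[C@H](CO)[C@@H](O)[C@H]1O` belongs to a different core; how its core differs from the core of compound 1 is not broken down here. In this assay compound 3 reaches only the limit of the assay, > 100000 nM, which is the limit described by the limit of > 100000 nM in this assay, at which 1 of the 3 values shown sits.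

Compound 4 `CSc1nc2cnsc2n1[C@@H]1O[C@H](CO)[C@@H](O)[C@H]1O` has not yet been measured in this assay. It differs from compound 3 by hydrogen in place of methyl on an aromatic carbon, the same change that separates compound 1 from compound 2. Because compound 3 sits at a limit > 100000 nM, the starting point for compound 4 is not a number but a bound, so the step from compound 1 to compound 2 can only suggest the direction. Compound 4 is expected to land at 100000 nM, between 20000 nM and 300000 nM, an estimated step of a number no higher from compound 3 to compound 4 (the limit leaves the size open).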

Compound 4, half-maximal inhibitory concentration: > 100000 nM
Compound 4 was reported as a limit; the forecaster's own chance of this, stated with the estimate: 60%; the middle value lies on the limit itself.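

In this assay, compound 3 and compound 4 both stop at a limit rather than a number, and no step can be read between them because of that shared limit: the limit of > 100000 nM in this assay, at which 2 of the 4 values shown sit.

The compounds shown leave open whether hydrogen in place of methyl on an aromatic carbon changes the activity of compound 3 and compound 4 at all, as it does between compound 1 and compound 2.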